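This account rests on a few compounds, and the source may have more. Where it says the series, first, only, none or still open, it means among the compounds named here.

Compound 1, `CC[C@H](C)[C@H](NC(=O)CN(c1ncnc2c1ncn2C1CCCCO1)C1CC1)C(=O)OCc1ccccc1`: 20.4%
Compound 2, `C[C@@H](O)[C@H](NC(=O)CN(c1ncnc2c1ncn2C1CCCCO1)C1CC1)C(=O)OCc1ccccc1`: 10.9%
Compound 3, `C[C@H](NC(=O)CN(c1ncnc2c1ncn2C1CCCCO1)C1CC1)C(=O)OCc1ccccc1`: 25.3%

The three compounds share one core and differ only in the side chain of the amino acid ester. Among the measured compounds shown here, in a functional assay on the whole organism (Tail, strain ICR) with Mus musculus as the target, in the tail flick test, with a stated time of 120 min, at a dose of 25 umol/kg by the oral route (on this read-out higher numbers stand for a stronger effect at the one dose given and lower numbers for a weaker effect), compound 3 gives the highest number of the three, though the step of a number 4.9 percentage points higher from compound 1 to compound 3 (within the scatter) is within the scatter, so compound 1 and compound 3 cannot be told apart; only the step of a number 14.4 percentage points higher from compound 2 to compound 3 (beyond the scatter) is beyond the scatter.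

Compound 4, `CSCC[C@H](NC(=O)CN(c1ncnc2c1ncn2C1CCCCO1)C1CC1)C(=O)OCc1ccccc1`, has not been measured. It differs from compound 3 in one place: (methylsulfanyl)methyl in place of hydrogen on a saturated chain carbon, two bonds along the chain from an amide-type nitrogen and a carbonyl carbon. Two measured steps speak to this, both enlarging the same side chain away from methyl. Going from methyl to sec-butyl, the reverse of a number 4.9 percentage points higher from compound 1 to compound 3 (within the scatter), changed little. Going from methyl to 1-hydroxyethyl, the reverse of a number 14.4 percentage points higher from compound 2 to compound 3 (beyond the scatter), lowered the number modestly. A chain carrying a sulfur acceptor but no donor is expected to behave between these two cases, so for compound 4 a step of a number 7.3 percentage points lower from compound 3 to compound 4 (within the scatter) is expected, mostly within the scatter. The estimate for compound 4 is therefore 18%, with a range from 8% to 30%.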

Compound 4, a percentage reported as activity, at one dose (the size of the read-out at that dose, not a potency): 28.7%
Beside the measured number, compound 4's estimate is 10.7 percentage points below it, within the range that was stated.
By their numbers in this assay, from the lowest: compounds 2, 1, 3 and 4 (each within the scatter of the next, the first and the last beyond it).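

In this assay, putting 2-(methylsulfanyl)ethyl in place of methyl on the amino acid side chain gives a number 3.4 percentage points higher from compound 3 to compound 4 (within the scatter), so this position takes a longer, sulfur-bearing chain with no loss that can be detected. That chain also cannot be told apart from sec-butyl, with a number 8.3 percentage points higher from compound 1 to compound 4 (within the scatter), but it clearly separates from 1-hydroxyethyl, with a number 17.8 percentage points higher from compound 2 to compound 4 (beyond the scatter). Among the compounds shown here, compound 2, the only one with a hydroxy group on its side chain, now lies beyond the scatter of two compounds rather than one, although it still cannot be told apart from the sec-butyl compound, with a number 9.5 percentage points lower from compound 1 to compound 2 (within the scatter).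

Nothing available gives a reason for these differences. On these data alone, it remains open how a side chain ending in an amine or a carboxylic acid would behave at this position, and, with only one dose and one time point, how the compounds compare in potency.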